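The compounds below may be only part of what the source reports. "The series", "measured", "known", "first", "only" and "open" are said of these compounds alone.

Measured compounds:
- compound 1 `COC(=O)c1ccc(CN(CCCc2c(N)nc(N)nc2O)c2cc(F)c(F)cc2[N+](=O)[O-])cc1` gives 66000 nM
- compound 2 `COC(=O)c1ccc(CN(CCCc2c(N)nc(N)nc2O)c2ccc([N+](=O)[O-])c(F)c2F)cc1` gives 55000 nM
- compound 3 `CC(C)(C)OC(=O)CCC(Nc1ccc(CN(CCCc2c(N)nc(N)nc2O)c2ccc([N+](=O)[O-])c(F)c2F)cc1)C(=O)OC(C)(C)C` gives 20000 nM

All three values come from a functional assay on CCRF-CEM cells (Homo sapiens) for cytotoxicity, in the absence of a further agent; on this read-out lower numbers stand for stronger inhibition and higher numbers for weaker inhibition. Compound 1 and compound 2 share one core and differ only in the aromatic group on the amine nitrogen; the change is 4,5-difluoro-2-nitrophenyl in place of 2,3-difluoro-4-nitrophenyl on an amine nitrogen. The step it made, a 1.2-fold higher number from compound 2 to compound 1 (0.08 log units; within the scatter), is small, so the two values are not distinguished here.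

Compound 3 carries a different core; the difference between the core of compound 3 and the core of compound 2 is not broken down here. On the side of the aromatic group on the amine nitrogen compound 3 matches compound 2. In this assay compound 3 gives 20000 nM, which is the lowest of the three numbers, beyond the scatter from both compound 2 and compound 1.

Compound 4 `CC(C)(C)OC(=O)CCC(Nc1ccc(CN(CCCc2c(N)nc(N)nc2O)c2cc(F)c(F)cc2[N+](=O)[O-])cc1)C(=O)OC(C)(C)C` has not yet been measured. It stands to compound 3 as compound 1 stands to compound 2: the change is 4,5-difluoro-2-nitrophenyl in place of 2,3-difluoro-4-nitrophenyl on an amine nitrogen, made at the same kind of place, on an amine nitrogen whose other neighbours are two saturated chain carbons. Among the measured compounds shown here, since the only earlier instance of this change, a 1.2-fold higher number from compound 2 to compound 1 (0.08 log units; within the scatter), stayed within the scatter, the expected step for compound 4 is likewise small, a 1.2-fold higher number from compound 3 to compound 4 (0.08 log units; within the scatter), resting on that one pair. Compound 4 is therefore estimated at 24000 nM, expected to lie between 10000 nM and 55000 nM.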

Compound 4, half-maximal inhibitory concentration: 1700 nM
Compound 4: middle estimate off by 14-fold (1.15 log units), on the high side; measured number outside the range, below it.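

In this assay, putting 4,5-difluoro-2-nitrophenyl in place of 2,3-difluoro-4-nitrophenyl on the amine nitrogen of the core with the two tert-butyl esters gave a large step, a 12-fold lower number from compound 3 to compound 4 (1.07 log units; beyond the scatter). Set beside the earlier instance on the core with the methyl ester, the same change did not carry over from one core to the other: the same change on two cores in this assay, a 1.2-fold higher number (0.08 log units; within the scatter) from compound 2 to compound 1 and a 12-fold lower number (1.07 log units; beyond the scatter) from compound 3 to compound 4, 14-fold (1.15 log units) apart, beyond the scatter of two such steps. In this series, then, the step seen on one of these cores was a poor guide to the step on the other, but two pairs cannot show which part of the core matters or why, and they give no rule for any further core.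

The compounds shown leave open which part of the larger core goes with the large step, the two tert-butyl esters or the rest of that core. The same two aromatic groups compared on a core with two carboxylic acids in place of those esters would help to separate these possibilities, and would show whether the large step appears on a third core at all.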